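The source may report more compounds than this note shows. Statements on the series, on what has been measured and on what is new or still open speak of the compounds shown alone.

Compounds measured in a functional assay on CHO-K1 cells for antagonist activity at transient receptor potential cation channel subfamily V member 1 (Homo sapiens), read by FLIPR; a lower number here means a stronger inhibitor, a higher number a weaker inhibitor:
compound 1 `CC(C(=O)NCc1ccc(C(F)(F)F)nc1N1CCC(C(F)(F)F)CC1)c1ccc(NS(C)(=O)=O)c(F)c1` gives 0.6 nM
compound 2 `CCCCOC1CCN(c2nc(C(F)(F)F)ccc2CNC(=O)C(C)c2ccc(NS(C)(=O)=O)c(F)c2)CC1` gives 3.5 nM

Compound 2 holds the higher of the two numbers. Among the measured compounds shown here, its nearest neighbour is compound 1, and the only recorded step between measured compounds runs a 5.8-fold higher number from compound 1 to compound 2 (0.77 log units; beyond the scatter); the change there is butoxy in place of trifluoromethyl on a saturated ring carbon.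

Compound 3 `CC(C(=O)NCc1ccc(C(F)(F)F)nc1N1CCCCCC1)c1ccc(NS(C)(=O)=O)c(F)c1` has not yet been measured in this assay. It differs from compound 2 in that (a group of 7 heavy atoms (6 carbon, 1 nitrogen; one seven-membered non-aromatic ring with 1 hetero atom) in place of a group of 11 heavy atoms (9 carbon, 1 nitrogen, 1 oxygen; one six-membered non-aromatic ring with 1 hetero atom), on an aromatic carbon). For the measured compounds named here, no measured step matches this change. The step of a 5.8-fold higher number from compound 1 to compound 2 (0.77 log units; beyond the scatter) swapped one substituent on the saturated ring for another while the ring itself stayed; here the whole ring is exchanged for an unsubstituted seven-membered one, so that step offers only a rough guide to how much the saturated ring region can move the number. Both measured compounds sit at low values, and the replacement keeps the shared core intact, so the expectation is a number close to those already seen. Compound 3 is estimated at 2 nM, with a range from 0.5 nM to 10 nM. Compound 3 is thus expected to show a 1.8-fold lower number from compound 2 to compound 3 (0.24 log units; within the scatter), a step without a clear direction beyond the scatter.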

Compound 3, inhibition constant: 0.8 nM
The estimate for compound 3 lay 2.5-fold (0.40 log units) above the measured number; measured number inside the range.
By their numbers in this assay, from the lowest: compounds 1 and 3 (each within the scatter of the next); then compound 2.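

In this assay, the position on the aromatic carbon next to the ring nitrogen accepts more than a change of substituent on the saturated ring, for azepan-1-yl in place of 4-(trifluoromethyl)piperidin-1-yl gives (a 1.3-fold higher number from compound 1 to compound 3 (0.12 log units; within the scatter)), so the whole ring can be exchanged with no change beyond the scatter. The same azepan-1-yl group, set against the larger butoxy-bearing group, gives (a 4.4-fold lower number from compound 2 to compound 3 (0.64 log units; beyond the scatter)), which shows that a saturated ring with no substituent at all can reach the low numbers and that, of the three, only compound 2 stands apart. Nothing given here accounts for either step.

The compounds shown leave open whether the higher number of compound 2 follows from the butoxy chain itself, which a methoxy group or a longer alkoxy chain on the same piperidine would help to settle. They also leave open how far the ring can change at this position, since a pyrrolidin-1-yl, an unsubstituted piperidin-1-yl or a morpholin-4-yl group would test ring size and a ring oxygen directly against the azepan-1-yl result.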